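The source may hold more compounds than are shown below. What is called first, only, known or untested is meant among the compounds shown, and "the series" means these compounds.

Compound 1 `CN(Cc1ccccc1)S(=O)(=O)c1ccc(NC(=O)NCc2ccncc2)cc1` is the most potent of the three compounds measured in an assay on isolated protein for activation of Nicotinamide phosphoribosyltransferase (Homo sapiens) (on this read-out lower numbers stand for an effect already at smaller amounts and higher numbers for an effect only at larger amounts of compound), where compound 1 gives 23 nM. Compound 2 `CCOC(=O)c1ccc(NC(=O)NCc2cocn2)cc1` gives 27600 nM in this assay, and compound 3 `CCOC(=O)c1ccc(NC(=O)NCc2cn[nH]c2)cc1` gives 1850 nM. For the measured compounds named here, the one step between compounds differing in a single place, a 15-fold lower number from compound 2 to compound 3 (1.17 log units; beyond the scatter), lies in the heterocycle on the saturated chain carbon and says nothing directly about the sulfonyl end of the molecule.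

Compound 4 `O=C(NCc1ccncc1)Nc1ccc(S(=O)(=O)c2ccccc2)cc1` differs from compound 1 at that other end: phenyl in place of benzyl(methyl)amino on a sulfonyl sulfur. Going by the values given here, no measured pair shows what this exchange does; the only shared feature with compound 1 is the pyridinylmethyl urea, which compounds 2 and 3 lack. Given that the urea substituent alone moves the number so far in this assay, and that the sulfonyl substituent of compound 1 is untested, a moderate weakening is expected for compound 4, with wide uncertainty. Compound 4 is therefore estimated at 100 nM, between 20 nM and 600 nM, corresponding to an expected step of a 4.3-fold higher number from compound 1 to compound 4 (0.64 log units; beyond the scatter).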

Compound 4, half-maximal effective concentration: 85 nM
Compound 4: middle estimate off by 1.2-fold (0.07 log units), on the high side; low and high end bracket the measured number.
By their numbers in this assay, from the lowest: compound 1; then compound 4; then compound 3; then compound 2.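

With the pyridinylmethyl urea held constant, the sulfonyl end receives its first direct test: a 3.7-fold higher number from compound 1 to compound 4 (0.57 log units; beyond the scatter) in this assay when phenyl takes the place of benzyl(methyl)amino on a sulfonyl sulfur. The exchange removes the sulfonamide nitrogen together with the methyl and benzyl groups, yet compound 4 still gives 85 nM in this assay, so the benzyl(methyl)amino group is not essential for a response at this level, although its loss carries a modest cost. No evidence at hand accounts for the size of this step.

Going by these compounds, it remains open which part of benzyl(methyl)amino matters, and a benzyl group or a dimethylamino group on the sulfonyl sulfur would help to separate those parts. On these data alone, how an ethyl ester in that place would compare on the same pyridinylmethyl urea also remains open.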